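Ethynyl in place of thiophen-2-yl on two cores

This account rests on a few compounds, and the source may have more. Where it says the series, first, only, none or still open, it means among the compounds named here.

Compound 3 `Cc1ncnc2c1c(-c1cccs1)cn2[C@@H]1O[C@H](CO)[C@@H](O)[C@H]1O` carries thiophen-2-yl on the core; in a functional assay on HL-60 cells (Homo sapiens) for antiproliferative activity, read by XTT assay, with a stated time of 72 h (on this read-out lower numbers stand for stronger inhibition and higher numbers for weaker inhibition), compound 3 gives 5730 nM. Compound 1 `C#Cc1cn([C@@H]2O[C@H](CO)[C@@H](O)[C@H]2O)c2ncnc(C)c12` carries ethynyl on the same core, and in this assay compound 1 gives 1110 nM. The change ethynyl in place of thiophen-2-yl on an aromatic carbon thus gives a 5.2-fold lower number from compound 3 to compound 1 (0.71 log units; beyond the scatter).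

Compound 2 `COc1nc(N)nc2c1c(-c1cccs1)cn2[C@@H]1O[C@H](CO)[C@@H](O)[C@H]1O` carries thiophen-2-yl on a different core; how the two cores differ is not broken down here. In this assay compound 2 gives only > 20000 nM, which is a limit of the assay and not a number (the limit of > 20000 nM in this assay, at which 1 of the 3 values shown sits).

Compound 4 `C#Cc1cn([C@@H]2O[C@H](CO)[C@@H](O)[C@H]2O)c2nc(N)nc(OC)c12` is the ethynyl counterpart of compound 2. For the measured compounds named here, the change ethynyl in place of thiophen-2-yl on an aromatic carbon is the same as the one from compound 3 to compound 1, with the place described in the same words. From the compounds shown here alone, because compound 2 sits only at the limit > 20000 nM, the starting point is unknown, so the expected step from compound 2 to compound 4 in this assay is taken from compound 1 as an at least 1.6-fold lower number from compound 2 to compound 4 (0.22 log units; that floor lies within the scatter) applied from the limit and is uncertain. Compound 4 is estimated at 12000 nM, expected within 3000 nM to 40000 nM.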

Compound 4, half-maximal inhibitory concentration: > 20000 nM
Compound 4 gave a limit, no number; the forecaster's own chance of this, stated with the estimate: 40%; at least 1.6-fold (0.22 log units) between middle value and limit.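

Compound 4 gives > 20000 nM in this assay, which is a limit of the assay and not a number. No step from compound 2 to compound 4 can be read, because both compounds sit at the same limit: the limit of > 20000 nM in this assay, at which 2 of the 4 values shown sit.

The compounds shown leave open whether ethynyl in place of thiophen-2-yl changes the number at all on the core of compound 2.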